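The source may report more compounds than this note shows. Statements on the series, on what has been measured and on what is new or still open speak of the compounds shown alone.

Compound 1 `Cc1nc(C)c(/C=C/C(=O)/C=C/c2ccccc2O)nc1C`: 3900 nM
Compound 2 `COc1cccc(/C=C/C(=O)/C=C/c2nc(C)c(C)nc2C)c1O`: 2190 nM
Compound 3 `Cc1nc(C)c(/C=C/C(=O)/C=C/c2ccc(Cl)cc2)nc1C`: 7490 nM

All three values come from a functional assay on A549/CDDP cells (Homo sapiens) for antiproliferative activity, read by MTT assay, with a stated time of 72 h; on this read-out higher numbers stand for weaker inhibition and lower numbers for stronger inhibition. Compound 1 stands within the scatter of both other compounds. Compound 4 `Cc1nc(C)c(/C=C/C(=O)/C=C/c2ccccc2[N+](=O)[O-])nc1C` has nitro in place of hydroxy on an aromatic carbon of compound 1 (nitro in place of hydroxy on an aromatic carbon). Within the data shown here, two measured steps bear on this change. One is a 1.8-fold lower number from compound 1 to compound 2 (0.25 log units; within the scatter), with methoxy in place of hydrogen on an aromatic carbon. The closer one also removes the hydroxy, with 4-chlorophenyl in place of 2-hydroxyphenyl, and it is a 1.9-fold higher number from compound 1 to compound 3 (0.28 log units; within the scatter). Neither is a direct precedent for nitro, but on these two steps no change beyond the scatter is expected in this assay. The estimate amounts to a 1.0-fold higher number from compound 1 to compound 4 (0.01 log units; within the scatter), an expected step. For compound 4 the expected value is 4000 nM, with an estimated range from 1500 nM to 10000 nM.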

Compound 4, half-maximal inhibitory concentration: 6390 nM
For compound 4 the middle estimate is 1.6-fold (0.20 log units) below the measured one, within the range that was stated.
By their numbers in this assay, from the lowest: compounds 2, 1, 4 and 3 (each within the scatter of the next, the first and the last beyond it).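

In this assay, nitro in place of hydroxy on the aromatic carbon ortho to a large group gives a 1.6-fold higher number from compound 1 to compound 4 (0.21 log units; within the scatter) with the rest of compound 1 unchanged. The earlier step that removed this hydroxy also replaced the whole 2-hydroxyphenyl with 4-chlorophenyl, whereas this one isolates the exchange at this place and still stays within the scatter. Nothing available accounts for this result. The compounds shown leave open whether an amine or a carboxylic acid on this same carbon would also stay within the scatter of compound 1.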